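Adding a Second Methoxy Group to a Cytotoxic Chalcone

This account rests on a few compounds, and the source may have more. Where it says the series, first, only, none or still open, it means among the compounds named here.

Measured so far:
compound 1 `COc1ccc(-c2cc(/C=C/C(=O)c3ccc(N)cc3)[nH]n2)cc1` with -93%
compound 2 `COc1cc(-c2cc(/C=C/C(=O)c3ccc(Cl)c(Cl)c3)[nH]n2)cc(OC)c1OC` with -50%
compound 3 `COc1ccc(C(=O)/C=C/c2cc(-c3cc(OC)c(OC)c(OC)c3)n[nH]2)cc1OC` with -86%

Of the compounds shown here, three built on the same core have been tested in a functional assay on HCC 2998 cells (Homo sapiens) for cytotoxicity, read by sulforhodamine B assay, with a stated time of 48 h, tested at 100 uM; a higher number here means a weaker effect of the compound at the concentration tested, a lower number a stronger effect. Compound 1 has the lowest number of the three, with -93%. Its nearest neighbour is compound 3, whose number is higher but within the scatter, so the two cannot be ranked. Within the data shown here, compound 2 sits far above both, and the only single-site step measured, a number 36 percentage points lower from compound 2 to compound 3 (beyond the scatter), shows how large a move the carbonyl-side ring can produce.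

Compound 4 `COc1ccc(-c2cc(/C=C/C(=O)c3ccc(N)cc3)[nH]n2)cc1OC` differs from compound 1 by methoxy in place of hydrogen on an aromatic carbon, on the ring attached to the core rather than on the carbonyl side. Among the measured compounds shown here, no measured step touches that position, so the step from compound 2 to compound 3 bears on it only loosely, as a sign that methoxy groups elsewhere are tolerated. Because compound 1 already gives -93%, little room remains for a lower number, and the expected change is a number 5 percentage points higher from compound 1 to compound 4 (within the scatter), nothing beyond the scatter. Compound 4 is therefore estimated at -88%, within a range from -100% to -62%.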

Compound 4, a percentage reported as activity, at one concentration (the size of the read-out at that concentration, not a potency): -91%
Compound 4: middle estimate off by 3 percentage points, on the high side; the range from low to high includes it.
By their numbers in this assay, from the lowest: compounds 1, 4 and 3 (each within the scatter of the next); then compound 2.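

Methoxy in place of hydrogen on an aromatic carbon, ortho to a methoxy group, gives in this assay a result of a number 2 percentage points higher from compound 1 to compound 4 (within the scatter), so the two compounds cannot be told apart. Among these compounds, this is the first measured step at this position, and it shows that the added methoxy group is tolerated here without loss of the effect seen with the amino-bearing carbonyl side of compound 1. No available evidence bears on this result.

From the compounds shown here alone, whether a hydroxyl group or a longer chain such as butoxy in the same place would also leave the number within the scatter remains open. Also open, going by these compounds, is whether the same methoxy step would matter more on a weaker background such as compound 2, which stands at -50%.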